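A few compounds are considered here, and "the series" means these few. Any claim that something is new, unique, unknown or untested is made for them only; others in the source may bear on it.

Measured compounds in the series:

- Compound 1, `COc1ncnc2c1c(-c1cc3ccccc3o1)cn2[C@@H]1O[C@H](CO)[C@@H](O)[C@H]1O`: 22400 nM
- Compound 2, `Nc1nc(N)c2c(-c3cc4ccccc4o3)cn([C@@H]3O[C@H](CO)[C@@H](O)[C@H]3O)c2n1`: > 100000 nM
- Compound 3, `COc1ncnc2c1c(-c1ccco1)cn2[C@@H]1O[C@H](CO)[C@@H](O)[C@H]1O`: 430 nM

All three were run in an ADME assay on BJ cells (Homo sapiens), read by MTT assay, with a stated time of 72 h; a higher number here means a weaker inhibitor, a lower number a stronger inhibitor. Compound 1 gives 22400 nM. Compound 3 gives 430 nM. For compound 2 the assay returns only a limit, > 100000 nM, and no number; this is the limit of > 100000 nM in this assay, at which 1 of the 3 values shown sits.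

Compound 1 and compound 3 share a core and differ in one place, (furan-2-yl in place of 1-benzofuran-2-yl on an aromatic carbon). For the measured compounds named here, that change produces a 52-fold lower number from compound 1 to compound 3 (1.72 log units; beyond the scatter), a step well beyond the scatter and the only measured step in the set. Compound 1 and compound 2 carry different cores; the difference between the two cores is not broken down here.

The untested member is compound 4, `Nc1nc(N)c2c(-c3ccco3)cn([C@@H]3O[C@H](CO)[C@@H](O)[C@H]3O)c2n1`. It relates to compound 2 as compound 3 relates to compound 1: the change is furan-2-yl in place of 1-benzofuran-2-yl on an aromatic carbon, and the surroundings of the place are the same in both pairs, so this is the same change made a second time on a different core.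

Expectation rests on one comparison. Since compound 1 to compound 3 gave a 52-fold lower number from compound 1 to compound 3 (1.72 log units; beyond the scatter), the step from compound 2 to compound 4 is estimated at an at least 8.3-fold lower number from compound 2 to compound 4 (0.92 log units; beyond the scatter) in this assay, with the caveat that compound 2 sits at a limit, so the starting point is itself unknown. Compound 4 is therefore expected to fall near 12000 nM, plausibly anywhere between 1500 nM and 100000 nM.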

Compound 4, half-maximal inhibitory concentration: > 100000 nM
Compound 4: a limit, no number (the forecaster's own chance of this, stated with the estimate: 30%); middle value at least 8.3-fold (0.92 log units) from the limit.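

No step can be read from compound 2 to compound 4, since both stand at the same limit and neither gives a number: the limit of > 100000 nM in this assay, at which 2 of the 4 values shown sit.

The compounds shown leave open whether furan-2-yl in place of 1-benzofuran-2-yl changes the read-out at all on the core of compound 2, and so whether the step from a 52-fold lower number from compound 1 to compound 3 (1.72 log units; beyond the scatter) carries over to that core.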